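The source may report more compounds than this note shows. Statements on the series, on what has been measured and on what is new or still open speak of the compounds shown alone.

Working notes on a small thiazole hydrazone set measured in a functional assay on A549 cells (Homo sapiens) for inhibition, read by MTT assay, with a stated time of 72 h; on this read-out higher numbers stand for weaker inhibition and lower numbers for stronger inhibition.

Compound 3 `Cc1nc(N(C)C(=O)NC(=O)c2c(F)cccc2F)sc1C(=O)N/N=C/c1cccc(C(F)(F)F)c1` and compound 2 `CN(C(=O)NC(=O)c1c(F)cccc1F)c1nc(C(F)(F)F)c(C(=O)N/N=C/c2cccc(C(F)(F)F)c2)s1` share a core that differs from that of compound 1 `CNc1nc(C)c(C(=O)N/N=C/c2cccc(C(F)(F)F)c2)s1`; the difference between the two cores is not broken down here. In this assay compound 3 gives 30.3 ug/mL. In this assay compound 2 gives 27.6 ug/mL. The change between them, (trifluoromethyl in place of methyl on an aromatic carbon), made a step of a 1.1-fold lower number from compound 3 to compound 2 (0.04 log units; within the scatter).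

Compound 1 is a separate case. In this assay compound 1 reaches only a limit, > 100 ug/mL, the limit described by the limit of > 100 ug/mL in this assay, at which 1 of the 3 values shown sits.

Compound 4 `CNc1nc(C(F)(F)F)c(C(=O)N/N=C/c2cccc(C(F)(F)F)c2)s1` has not been measured. It differs from compound 1 by trifluoromethyl in place of methyl on an aromatic carbon, the same kind of change as from compound 3 to compound 2, though around the place the ring atom two ring bonds away bears a methylamino group (2 heavy atoms) rather than a large group. Since compound 3 to compound 2 stayed within the scatter, a 1.1-fold lower number from compound 3 to compound 2 (0.04 log units; within the scatter), the step of a number no higher from compound 1 to compound 4 (the limit leaves the size open) is expected to be small as well, and since compound 1 sits at the limit > 100 ug/mL, compound 4 is likely to sit there too. The expected value for compound 4 is 100 ug/mL, between 40 ug/mL and 300 ug/mL.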

Compound 4, half-maximal inhibitory concentration: > 100 ug/mL
Compound 4: only a limit was reported; the forecaster's own chance of this, stated with the estimate: 65%; the middle value lies on the limit itself.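

In this assay, compound 1 and compound 4 both reach only a limit of the assay, so no step between them can be read: the limit of > 100 ug/mL in this assay, at which 2 of the 4 values shown sit.

The compounds shown leave open whether trifluoromethyl in place of methyl makes any difference to the read-out on the core of compound 1.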